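The source may report more compounds than this note shows. Statements on the series, on what has been measured and on what is new or still open speak of the compounds shown alone.

Series notes. Among the compounds with values here, compound 1 `COc1ncnc2c1c(-c1ccsc1)cn2[C@@H]1O[C@H](CO)[C@@H](O)[C@H]1O` is the only member with a number in an ADME assay on MRC5 cells (Homo sapiens), read by MTT assay, with a stated time of 72 h (a lower number here means a stronger inhibitor, a higher number a weaker inhibitor), where compound 1 gives 75300 nM. Compound 2 `CNc1ncnc2c1c(-c1ccsc1)cn2[C@@H]1O[C@H](CO)[C@@H](O)[C@H]1O` returns only a limit in this assay, > 100000 nM. Within the data shown here, the single measured step, an at least 1.3-fold higher number from compound 1 to compound 2 (0.12 log units; that floor lies within the scatter), runs against the limit of > 100000 nM in this assay, at which 1 of the 2 values shown sits, and alters a different place than the one considered here. Compound 3 `COc1ncnc2c1c(I)cn2[C@@H]1O[C@H](CO)[C@@H](O)[C@H]1O` differs from compound 1 by iodo in place of thiophen-3-yl on an aromatic carbon. Among the measured compounds shown here, no measured step touches that place, so no direction can be drawn from the data. A step within the scatter is therefore expected, a 1.1-fold higher number from compound 1 to compound 3 (0.03 log units; within the scatter). Compound 3 is estimated at 80000 nM, with a range from 30000 nM to 200000 nM.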

Compound 3, half-maximal inhibitory concentration: 63000 nM
Compound 3: middle estimate off by 1.3-fold (0.10 log units), on the high side; measured number inside the range.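

In this assay, iodo in place of thiophen-3-yl on this aromatic carbon gives a 1.2-fold lower number from compound 1 to compound 3 (0.08 log units; within the scatter). Within the data shown here, this is the first measured step at this place, and it does not separate a five-membered aromatic ring from a single iodine atom. Compound 2 returns only a limit, not a number: the limit of > 100000 nM in this assay, at which 1 of the 3 values shown sits. Going by these compounds, it remains open whether an amine, a carboxylic acid or a longer alkyl chain at this place would shift the number beyond the scatter, and in which direction.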